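From Methoxy to Benzyloxy on a Shared Core

This account rests on a few compounds, and the source may have more. Where it says the series, first, only, none or still open, it means among the compounds named here.

Compound 1 `CC(C)CC(=O)Nc1nc2ccc(NC(=O)c3c(Cl)cccc3Cl)cc2s1` gives 0.012 ug/mL in a functional assay on WI-38 VA13 cells (Homo sapiens) for cytotoxicity; on this read-out higher numbers stand for an effect only at larger amounts of compound and lower numbers for an effect already at smaller amounts.
Compound 2 `COC(=O)Nc1nc2ccc(NC(=O)c3c(Cl)cccc3Cl)cc2s1` gives 0.0095 ug/mL in this assay.

Compound 2 holds the lower of the two numbers, yet its gap to compound 1 is within the scatter, so the two are not told apart. Compound 3 `O=C(Nc1nc2ccc(NC(=O)c3c(Cl)cccc3Cl)cc2s1)OCc1ccccc1` differs from compound 2 by phenyl in place of hydrogen on a saturated chain carbon bound to an oxygen next to a carbonyl group. Within the data shown here, the one measured step, a 1.3-fold lower number from compound 1 to compound 2 (0.10 log units; within the scatter), swapped a group on the carbonyl carbon and stayed within the scatter; it bears only loosely on this change, where the oxygen side grows instead. No shift beyond the scatter is therefore expected, a 1.3-fold higher number from compound 2 to compound 3 (0.10 log units; within the scatter). For compound 3 the estimate is 0.012 ug/mL, ranging from 0.004 ug/mL to 0.04 ug/mL.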

Compound 3, half-maximal effective concentration: 0.018 ug/mL
Compound 3: middle estimate off by 1.5-fold (0.18 log units), on the low side; low and high end bracket the measured number.
By their numbers in this assay, from the lowest: compounds 2, 1 and 3 (each within the scatter of the next).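

On the oxygen next to the carbonyl group, methoxy can become benzyloxy with a 1.9-fold higher number from compound 2 to compound 3 (0.28 log units; within the scatter) in this assay, so adding a phenyl at this saturated chain carbon does not tell the two compounds apart. The remaining pair shows a 1.5-fold higher number from compound 1 to compound 3 (0.18 log units; within the scatter), so all three compounds stay within the scatter of one another. Nothing available explains why these changes leave the number so little moved.

Still open, going by these compounds, is whether an amine or a carboxylic acid on that phenyl ring would keep the number within the scatter. A longer chain in place of benzyl poses the same question.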